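The compounds below may be only part of what the source reports. "The series", "measured", "known", "first", "only" and "open" are said of these compounds alone.

Measured so far in a functional assay on K562 cells (Homo sapiens) for inhibition, read by trypan blue exclusion, with a stated time of 72 h; a lower number here means a stronger inhibitor, a higher number a weaker inhibitor:

compound 1, `Cn1c(=O)c(S(=O)(=O)c2ccc(F)cc2F)cc2cnc(Nc3cccc4[nH]ccc34)nc21`: 1500 nM
compound 2, `Cn1c(=O)c(S(=O)(=O)c2ccc(F)cc2)cc2cnc(Nc3cccc4[nH]ccc34)nc21`: 750 nM
compound 3, `Cn1c(=O)c(S(=O)(=O)Cc2ccc(F)cc2)cc2cnc(Nc3ccc4[nH]ccc4c3)nc21`: 30000 nM

Compound 3 stands at the top of the three numbers; its nearest neighbour is compound 1, and the gap to compound 1 and to compound 2 is in each case beyond the scatter, so compound 3 is the weakest inhibitor among the measured set. Compound 4, `Cn1c(=O)c(S(=O)(=O)c2ccc(C(=O)O)cc2)cc2cnc(Nc3ccc4[nH]ccc4c3)nc21`, is the unmeasured step from compound 3: 4-carboxyphenyl in place of 4-fluorobenzyl on a sulfonyl sulfur. Within the data shown here, the only single-point step among measured pairs is a 2.0-fold lower number from compound 1 to compound 2 (0.30 log units; within the scatter), which concerns a fluoro on the aromatic ring of the sulfonyl group rather than the sulfonyl-to-ring link itself, and it stays within the scatter. Among the measured compounds shown here, no single step ties compound 3 to compound 1 or compound 2; those pairs differ at more than one place, and their values show only that the two arylsulfonyl compounds sit well below compound 3. Compound 4 carries an arylsulfonyl like compounds 1 and 2 but keeps the indole of compound 3, so the direction of the step in this assay is expected to be downward, with wide uncertainty on its size. The step of a 5.0-fold lower number from compound 3 to compound 4 (0.70 log units; beyond the scatter) is the estimate. For compound 4 the expected value is 6000 nM, within 1500 nM to 30000 nM.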

Compound 4, half-maximal inhibitory concentration: 5000 nM
The estimate for compound 4 lay 1.2-fold (0.08 log units) above the measured number; the measured number falls inside the stated range.
By their numbers in this assay, from the lowest: compounds 2 and 1 (each within the scatter of the next); then compound 4; then compound 3.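

In this assay, 4-carboxyphenyl in place of 4-fluorobenzyl on a sulfonyl sulfur gives a 6.0-fold lower number from compound 3 to compound 4 (0.78 log units; beyond the scatter), with the rest of the molecule unchanged, so the group on this sulfur can move the number by more than the scatter. Among these compounds, the only earlier single-place step, a 2.0-fold lower number from compound 1 to compound 2 (0.30 log units; within the scatter), concerned a fluoro on the aromatic ring of the sulfonyl group and gave no such reading. The new step changes the carbon-only ring's attachment and its substituent together, so it cannot be assigned to either part, and no measurement on hand gives a reason for it.

A 4-fluorophenyl or a 4-carboxybenzyl on the same sulfonyl sulfur would separate the two parts of the change, while a methyl ester or a primary amide in place of the carboxylic acid would test whether that group itself matters. On these data alone, compound 4 differs from compound 1 and compound 2 in more than one place, so how much of their gap comes from the sulfonyl substituent and how much from the rest of the molecule stays open.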